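From pyrazolyl to pyridin-2-yl on the shared core

The compounds below may be only part of what the source reports. "The series", "measured", "known", "first", "only" and "open" are said of these compounds alone.

Compound 2 `Cc1nn(-c2ccccc2)cc1/C=N/Nc1nc(Nc2ccccc2)nc(Nc2ccc(S(N)(=O)=O)cc2)n1` stands at the lower of the two numbers shown in a functional assay on MDA-MB-435 cells (Homo sapiens) for inhibition, read by sulforhodamine B assay, with a stated time of 48 h (a higher number here means a weaker inhibitor of growth, a lower number a stronger inhibitor of growth), where compound 2 gives 1770 nM. Within the data shown here, its only neighbour is compound 1 `NS(=O)(=O)c1ccc(Nc2nc(N/N=C/c3ccc(C(F)(F)F)cc3)nc(Nc3ccccc3)n2)cc1`, which in this assay gives 2070 nM; the single measured step, a 1.2-fold lower number from compound 1 to compound 2 (0.07 log units; within the scatter), does not separate the two beyond the scatter, so neither compound can be called the stronger inhibitor of growth.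

Compound 3 `NS(=O)(=O)c1ccc(Nc2nc(N/N=C/c3ccccn3)nc(Nc3ccccc3)n2)cc1` differs from compound 2 by one exchange: pyridin-2-yl in place of 3-methyl-1-phenyl-1H-pyrazol-4-yl on a carbon with a double bond to nitrogen. Among the measured compounds shown here, the only step that bears on this position is a 1.2-fold lower number from compound 1 to compound 2 (0.07 log units; within the scatter), which shows that replacing one group on that carbon with a quite different one left the number essentially unchanged. With a single step of that kind and no other information on this position, a move of a similar size is expected here, that is, none beyond the scatter, and the expected step is a 1.1-fold higher number from compound 2 to compound 3 (0.03 log units; within the scatter). On that basis compound 3 is estimated to give 1900 nM in this assay, with a range from 800 nM to 4500 nM.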

Compound 3, concentration for 50% growth inhibition: 910 nM
Compound 3: the middle estimate sits 2.1-fold (0.32 log units) above what was measured; measured number inside the range.
By their numbers in this assay, from the lowest: compounds 3, 2 and 1 (each within the scatter of the next, the first and the last beyond it).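

In this assay, among these compounds, the step to pyridin-2-yl from 4-(trifluoromethyl)phenyl, a 2.3-fold lower number from compound 1 to compound 3 (0.36 log units; beyond the scatter), is the first on this carbon with a double bond to nitrogen to pass the scatter, showing that the group here can shift the number, if only modestly, towards stronger inhibition of growth. The exchange for 3-methyl-1-phenyl-1H-pyrazol-4-yl, a 1.9-fold lower number from compound 2 to compound 3 (0.29 log units; within the scatter), stays within the scatter, so compound 3 cannot be separated from compound 2, even though pyridin-2-yl has 6 heavy atoms and the group it replaces has 12 heavy atoms. No measurement is available that accounts for either step.

Among the compounds shown here, with only three groups at this place, it remains open whether the ring nitrogen of pyridin-2-yl matters, a question that an unsubstituted phenyl, pyridin-3-yl or pyridin-4-yl group on the same carbon would address. All three compounds also share the remainder of the structure, so they leave open how the number would respond to changes elsewhere on the shared core, such as a carboxylic acid in place of the sulfonamide.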